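Piperidinyl for Methoxy on a Phenoxyalkyl Thiourea

A few compounds are considered here, and "the series" means these few. Any claim that something is new, unique, unknown or untested is made for them only; others in the source may bear on it.

Measured compounds:
compound 1 `NC(=S)Nc1cccc(OCCCCCCCc2ccccc2)c1`, with 23000 nM
compound 2 `COc1ccc(OCCCCCOc2cccc(NC(N)=S)c2)cc1`, with > 50000 nM

In an ADME assay on Ava5 cells (Homo sapiens) for cytotoxicity (a higher number here means that more compound is tolerated, a lower number that less compound is tolerated), compound 1 gives 23000 nM. For compound 2 only a limit of the assay is known, > 50000 nM. That reading is the limit of > 50000 nM in this assay, at which 1 of the 2 values shown sits. Compound 2 therefore stands at the upper edge of what this assay reports, and the gap between it and compound 1 cannot be put into a number.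

Compound 3 `NC(=S)Nc1cccc(OCCCCCOc2ccc(N3CCCCC3)cc2)c1` has not been measured. It differs from compound 2 in one place: piperidin-1-yl in place of methoxy on an aromatic carbon. For the measured compounds named here, no pair of measured compounds shares this change, so no measured step guides the expectation in this assay. Given that the starting point is a limit, any step either way could remain hidden, and no change beyond the scatter is assumed. Compound 3 is expected to give 40000 nM in this assay, estimated between 15000 nM and 100000 nM. The expected step is an at least 1.2-fold lower number from compound 2 to compound 3 (0.09 log units; that floor lies within the scatter), with a fair chance that the assay again reports only a limit.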

Compound 3, half-maximal cytotoxic concentration: 12000 nM
For compound 3 the middle estimate is 3.3-fold (0.52 log units) above the measured one; the whole stated range lies above it.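

The earlier compounds shown here gave no sign that this position matters in this assay. Piperidin-1-yl in place of methoxy on this aromatic carbon, para to a large group, now gives an at least 4.1-fold lower number from compound 2 to compound 3 (0.61 log units; beyond the scatter), so less compound is tolerated with the larger group and the reading comes away from the edge of the assay to a real number. The true size of the step stays unknown, and its printed size is only a floor, because compound 2 stands at a limit: the limit of > 50000 nM in this assay, at which 1 of the 3 values shown sits.

The compounds shown leave open whether the step follows the ring as a whole or the nitrogen joined to the aromatic carbon, which a cyclohexyl or a dimethylamino group at the same place would help to separate. They also leave open whether a morpholine ring there, or a longer chain in the linker, would give a similar step.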